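Closing the tertiary alcohol of compound 2 into an oxirane

The source may hold more compounds than are shown below. What is called first, only, known or untested is meant among the compounds shown, and "the series" means these compounds.

Two esters have been measured in a physicochemical assay for lipophilicity; on this read-out higher numbers stand for higher lipophilicity and lower numbers for lower lipophilicity. Compound 1 `COC(=O)/C=C(C)/C=C/CC(C)CCCC(C)(C)OC` gives 5 in this assay. Compound 2 `CCOC(=O)/C=C(C)/C=C/CC(C)CCCC(C)(C)O` gives 4.65 in this assay, the lower of the two numbers, with compound 1 standing higher by a margin beyond the usual scatter. The two compounds differ in more than one place, so their values are only compared, not traced to a single change.

Compound 3 `CCOC(=O)/C=C(C)/C=C/CC(C)CCC1OC1(C)C` has not yet been measured in this assay. Its relation to compound 2 is a single change: 3,3-dimethyloxiran-2-yl in place of 2-hydroxy-2-methylpropyl on a saturated chain carbon, four bonds along the chain from a double-bonded chain carbon. The group that leaves carries one hydrogen-bond donor; the group that enters carries none. On that basis compound 3 is expected to read higher than compound 2 in this assay, by a step of a number 0.65 log units higher from compound 2 to compound 3 (beyond the scatter) that should exceed the scatter. The estimate for compound 3 is 5.3, with a range from 4.8 to 5.8.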

Compound 3, partition coefficient: 4.76
Compound 3: middle estimate off by 0.54 log units, on the high side; measured number outside the range, below it.
By their numbers in this assay, from the lowest: compounds 2, 3 and 1 (each within the scatter of the next, the first and the last beyond it).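

In this assay, going by these compounds alone, the exchange of 2-hydroxy-2-methylpropyl for 3,3-dimethyloxiran-2-yl on a saturated chain carbon gives a number 0.11 log units higher from compound 2 to compound 3 (within the scatter) at this position, the first single change that can be read here. A group with 1 hydrogen-bond donor gives way to a ring-bearing group with 0 hydrogen-bond donors, at 5 heavy atoms on each side, and the two compounds cannot be told apart on this read-out. Nothing shown bears on why the two groups read alike.

Still open, as far as these compounds go, is how the methoxy end of compound 1 would read on the ethyl ester, since compound 1 also differs from compound 2 in its ester. Also open, from the compounds shown here alone, is how a primary amine in place of the oxirane, or a carboxylic acid in place of the ester, would read.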